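Trifluoromethyl to methoxy on a series known only by limits

This account rests on a few compounds, and the source may have more. Where it says the series, first, only, none or still open, it means among the compounds named here.

Among the measured compounds shown here, the read-out for this series is an ADME assay on HCT-116 cells (Homo sapiens) for cytotoxicity, read by CellTiter-Glo, with a stated time of 72 h (a lower number here means a stronger inhibitor, a higher number a weaker inhibitor), and no tested compound has yet returned a number. Compound 1 `CC1CCN(C2CCN(S(=O)(=O)c3cccc4ccccc34)CC2)CC1` gives > 10000 nM as a limit of the assay. Compound 2 `CC1CCN(C2CCN(S(=O)(=O)c3ccccc3-c3ccc(C(F)(F)F)cc3)CC2)CC1` gives > 5000 nM as a limit of the assay. Compound 3 `Cc1cc(C)c(S(=O)(=O)NC2CCN(C3CCN(C)CC3)CC2)c(C)c1` gives > 5000 nM as a limit too. Compound 2 therefore stands only at a limit, as do the two other compounds, and no order among the three can be read from these results.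

Compound 4 `COc1ccc(-c2ccccc2S(=O)(=O)N2CCC(N3CCC(C)CC3)CC2)cc1` differs from compound 2 in one place, with methoxy in place of trifluoromethyl on an aromatic carbon, para to a large group methoxy in place of trifluoromethyl on an aromatic carbon in the change from 4-(trifluoromethyl)phenyl to 4-methoxyphenyl. For the measured compounds named here, no measured pair shows what this change does in this assay so no direction is favoured. The expected step that the limit leaves unreadable from compound 2 to compound 4 is none beyond the scatter. This expectation rests on compound 2 with its limit of > 5000 nM in the same assay, and another limit is the most likely report. For compound 4 the estimated value is 8000 nM with an expected range from 3500 nM to 20000 nM as the likely span.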

Compound 4, half-maximal inhibitory concentration: > 5000 nM
Compound 4: no number, only a limit; the forecaster's own chance of this, stated with the estimate: 80%; the middle value is on the limit's open side.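

In this assay, among the compounds shown here, compound 2 and compound 4 both stand only at a limit, and no step between them can be read. The compounds shown leave open whether methoxy in place of trifluoromethyl on an aromatic carbon shifts this read-out at all, and none of them yet gives a number that could anchor a comparison.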